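A few compounds are considered here, and "the series" means these few. Any claim that something is new, unique, unknown or untested is made for them only; others in the source may bear on it.

Compound 3 `O=C1C=CC(OCC(F)(F)F)N1c1ccc(Cl)cc1F` gives 8320 nM in a functional assay on HeLa cells (Homo sapiens) for inhibition (on this read-out higher numbers stand for weaker inhibition and lower numbers for stronger inhibition), the lowest of the two numbers shown, and compound 1 `Cc1ccc(N2C(=O)C=CC2OCC(F)(F)F)cc1` at 9380 nM lies within the scatter of it. Compound 2 `O=C1C=CC(OCC(F)(F)F)N1c1ccccc1` gives > 100000 nM, which is not a number but (the limit of > 100000 nM in this assay, at which 1 of the 3 values shown sits). For the measured compounds named here, the only measured step, an at least 10-fold higher number from compound 1 to compound 2 (1.02 log units; beyond the scatter), removed a group from the ring on the nitrogen and raised the number far beyond the scatter. Compound 4 `O=C1C=CC(OCC(F)(F)F)N1c1ccccc1F` differs from compound 3 by hydrogen in place of chloro on an aromatic carbon, again removing a group from that ring, para to a large group. On the strength of that one step a clear rise is expected, a 4.8-fold higher number from compound 3 to compound 4 (0.68 log units; beyond the scatter), though a chloro group is not a methyl. Compound 4 is therefore estimated at 40000 nM, between 12000 nM and 130000 nM.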

Compound 4, half-maximal inhibitory concentration: 19300 nM
Beside the measured number, compound 4's estimate is 2.1-fold (0.32 log units) above it, within the range that was stated.
By their numbers in this assay, from the lowest: compounds 3 and 1 (each within the scatter of the next); then compound 4. At a limit, above all of these: compound 2.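

Chloro at this place, para to a large group, makes a real but limited difference, with a 2.3-fold higher number from compound 3 to compound 4 (0.37 log units; beyond the scatter) once it gives way to hydrogen. The fluoro group also counts on its own, with an at least 5.1-fold lower number from compound 2 to compound 4 (0.71 log units; beyond the scatter) when it replaces hydrogen, so inhibition can be measured here without any group at the chloro place. The value of compound 2 is a limit and not a number: the limit of > 100000 nM in this assay, at which 1 of the 4 values shown sits.

On these data alone, what an amine or a carboxylic acid at the chloro place would do remains open.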